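Fluoromethyl in Place of Hydroxymethyl: Expected Cytotoxicity of Compound 4

The compounds below may be only part of what the source reports. "The series", "measured", "known", "first", "only" and "open" are said of these compounds alone.

Three compounds have been measured in a functional assay on HeLa cells (Homo sapiens) for cytotoxicity, read by WST assay, with a stated time of 48 h; a higher number here means a weaker inhibitor, a lower number a stronger inhibitor:

compound 1 `CCCCC[C@H](C(C)C)C(c1ccc(O)c(OC)c1)c1ccc(O)c(OC)c1`: 9200 nM
compound 2 `COc1cc(C(c2ccc(O)c(OC)c2)[C@H](C)[C@H](C)CF)ccc1O`: 75000 nM
compound 3 `COc1cc(C(c2ccc(O)c(OC)c2)[C@H](C)[C@H](C)CO)ccc1O`: > 100000 nM

Compound 1 is the strongest inhibitor of the three. On these data alone, compound 3 gives only a limit of the assay, (the limit of > 100000 nM in this assay, at which 1 of the 3 values shown sits), so its true number is unknown. The two short branched chains each cost potency: an 8.2-fold higher number from compound 1 to compound 2 (0.91 log units; beyond the scatter) and an at least 10-fold higher number from compound 1 to compound 3 (1.03 log units; beyond the scatter). Between the two of them, an at least 1.3-fold higher number from compound 2 to compound 3 (0.12 log units; that floor lies within the scatter), so the swap of hydroxy for fluoro on the chain is not resolved beyond the scatter.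

Compound 4 `COc1cc(C(c2ccc(O)c(OC)c2)[C@H](CF)C(C)C)ccc1O` is not yet measured. It differs from compound 3 in one place: 1-(fluoromethyl)-2-methylpropyl in place of 2-(hydroxymethyl)-1-methylpropyl on a saturated chain carbon bound to two aromatic carbons. The step that bears on it most is that from compound 2 to compound 3, where fluorine gave the lower number, though by an amount within the scatter. Compound 4 is therefore expected to land near compound 2, which means an expected downward step an at least 1.2-fold lower number from compound 3 to compound 4 (0.09 log units; that floor lies within the scatter), its size uncertain since compound 3 is only a limit. The estimate for compound 4 is 80000 nM, with a range from 30000 nM to 200000 nM.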

Compound 4, half-maximal inhibitory concentration: 19000 nM
For compound 4 the middle estimate is 4.2-fold (0.62 log units) above the measured one; the whole stated range lies above it.
By their numbers in this assay, from the lowest: compound 1; then compound 4; then compound 2. At a limit, above all of these: compound 3.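

In this assay, the placing of the fluoromethyl group on the branched chain matters: 1-(fluoromethyl)-2-methylpropyl in place of 2-(fluoromethyl)-1-methylpropyl gives a 3.9-fold lower number from compound 2 to compound 4 (0.60 log units; beyond the scatter), while the change from the longer 1-isopropylhexyl chain, at a 2.1-fold higher number from compound 1 to compound 4 (0.31 log units; beyond the scatter), costs less than it did with either earlier short chain. Compound 3 gives only a limit of the assay: the limit of > 100000 nM in this assay, at which 1 of the 4 values shown sits. That limit makes an at least 5.2-fold lower number from compound 3 to compound 4 (0.72 log units; beyond the scatter) a floor, yet even this floor shows that a short chain at this place can change the number beyond the scatter.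

On these data alone, it remains open whether 1-(hydroxymethyl)-2-methylpropyl or 1-(aminomethyl)-2-methylpropyl at this place would behave like the fluorinated chain of compound 4. The share of the fluorine and the share of the chain arrangement therefore cannot yet be told apart.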